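This account rests on a few compounds, and the source may have more. Where it says the series, first, only, none or still open, it means among the compounds named here.

Compound 1 `O=C(CI)NCCCC(=O)Nc1cn([C@H]2C[C@H](O)[C@@H](CO)O2)c(=O)[nH]c1=O`: 3100000 nM
Compound 2 `Cc1cn([C@H]2C[C@H](O)[C@@H](C[S+]([O-])CCC(=O)O)O2)c(=O)[nH]c1=O`: 130000 nM

Both were tested in an assay on BHK21 (C13) cells (Mesocricetus auratus) for inhibition of thymidine kinase, cytosolic (Cricetulus griseus), using Lineweaver-Burk analysis; on this read-out higher numbers stand for weaker inhibition and lower numbers for stronger inhibition. Of the two numbers, compound 2 holds the lower one, while compound 1 stands a good deal higher, a gap well beyond the usual scatter of repeat measurements. Compound 3 `Cc1cn([C@H]2C[C@H](O)[C@@H](C[S+]([O-])CCCC(=O)O)O2)c(=O)[nH]c1=O` is built from compound 2 by a single change: carboxymethyl in place of carboxy on a saturated chain carbon, two bonds along the chain from a sulfur. In plain terms, the chain carrying the acid is lengthened, and nothing else moves. Within the data shown here, no pair of measured compounds shows what such a lengthening does in this assay, so there is nothing here to point to a large effect in either direction; the expectation is a step no larger than the usual scatter, leaning slightly toward a weaker reading. On that basis compound 3 is expected to give about 160000 nM in this assay, with a likely range from 55000 nM to 480000 nM. That amounts to an expected 1.2-fold higher number from compound 2 to compound 3 (0.09 log units; within the scatter).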

Compound 3, half-maximal inhibitory concentration: 2500000 nM
The estimate for compound 3 lay 16-fold (1.19 log units) below the measured number; measured number above the stated range.
By their numbers in this assay, from the lowest: compound 2; then compounds 3 and 1 (each within the scatter of the next).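

In this assay, putting carboxymethyl in place of carboxy on a saturated chain carbon, two bonds along the chain from a sulfur, gives a 19-fold higher number from compound 2 to compound 3 (1.28 log units; beyond the scatter), which means clearly weaker inhibition. Among these compounds, this is the first sign that the length of the chain carrying the acid matters at this position: a small lengthening, with the rest of the molecule unchanged, is enough to produce a large loss. It is a single step between two compounds, so it shows no general trend, and no measurement at hand explains why the step is so large. From the compounds shown here alone, whether a still longer chain would weaken inhibition further remains open. So does the effect of an ester or an amine at the end of the chain in place of the carboxylic acid.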